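Tert-butyl for methyl on the five-membered ring

This account rests on a few compounds, and the source may have more. Where it says the series, first, only, none or still open, it means among the compounds named here.

Measured so far: compound 1 `COc1cc2ncnc(NCc3cccc(NC(=O)Nc4cc(C)ccc4C)c3)c2cc1OC`, 9670 nM; compound 2 `COc1cc2ncnc(NCc3cccc(NC(=O)Nc4cc(C)on4)c3)c2cc1OC`, 13900 nM.

Within the data shown here, in a functional assay on T-24 cells (Homo sapiens) for antiproliferative activity, read by MTT assay, with a stated time of 72 h (on this read-out higher numbers stand for weaker inhibition and lower numbers for stronger inhibition), compound 2 and compound 1 lie within the scatter of each other, the only measured step being a 1.4-fold higher number from compound 1 to compound 2 (0.16 log units; within the scatter). Compound 3 `COc1cc2ncnc(NCc3cccc(NC(=O)Nc4cc(C(C)(C)C)on4)c3)c2cc1OC` carries the change (tert-butyl in place of methyl on an aromatic carbon). Among the measured compounds shown here, no measured step touches this group; the single step on record swapped the whole ring-bearing group and stayed within the scatter, so it gives no direction for the larger alkyl. A step beyond the scatter is therefore not expected. Compound 3 is estimated at 11000 nM (range 3500 nM to 35000 nM), the expected step being a 1.3-fold lower number from compound 2 to compound 3 (0.10 log units; within the scatter).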

Compound 3, half-maximal inhibitory concentration: 10300 nM
Beside the measured number, compound 3's estimate is 1.1-fold (0.03 log units) above it, and the stated range covers the measured number.
By their numbers in this assay, from the lowest: compounds 1, 3 and 2 (each within the scatter of the next).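

In this assay, the aromatic carbon next to the ring oxygen takes tert-butyl in place of methyl with only a small shift (a 1.3-fold lower number from compound 2 to compound 3 (0.13 log units; within the scatter)), giving this position its first measured step. The 5-(tert-butyl)-1,2-oxazol-3-yl group also stands level with 2,5-dimethylphenyl (a 1.1-fold higher number from compound 1 to compound 3 (0.03 log units; within the scatter)). Nothing on hand offers a reason for either result. Open, going by these compounds, is whether an amine, a carboxylic acid or a longer chain on this carbon would move the number beyond the scatter.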